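The source may hold more compounds than are shown below. What is called first, only, known or untested is meant among the compounds shown, and "the series" means these compounds.

Three chalcones sharing one core have been measured in a functional assay, read by Griess assay, with a stated time of 2.5 h; on this read-out higher numbers stand for weaker inhibition and lower numbers for stronger inhibition. Compound 1 `COc1cc(OC)c(OC)cc1/C=C/C(=O)c1ccc(C)cc1` gives 2.18 ug/mL. Compound 2 `COc1cc(OC)c(OC)cc1/C=C/C(=O)c1ccc([N+](=O)[O-])cc1` gives 1.98 ug/mL, and compound 3 `COc1cc(OC)c(OC)cc1/C=C/C(=O)c1ccccc1` gives 2.01 ug/mL. None of the steps among them reaches beyond the scatter: a 1.1-fold lower number from compound 1 to compound 2 (0.04 log units; within the scatter), a 1.1-fold lower number from compound 1 to compound 3 (0.04 log units; within the scatter) and a 1.0-fold higher number from compound 2 to compound 3 (0.01 log units; within the scatter). Compound 3 therefore stands second highest of the three numbers, with compound 2 nearest and compound 1 furthest, both within the scatter of it.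

Compound 4 `COc1cc(OC)c(OC)cc1/C=C/C(=O)c1ccc(Br)cc1` differs from compound 3 by bromo in place of hydrogen on an aromatic carbon. All three measured steps bear on this change, since each replaces one group by another on the same aromatic carbon, and each stayed within the scatter. On that basis no step beyond the scatter is expected in this assay, in either direction. Compound 4 is accordingly estimated to give 2 ug/mL, with a range from 1 ug/mL to 4 ug/mL. The step that this estimate means, a 1.0-fold lower number from compound 3 to compound 4 (0.00 log units; within the scatter), is expected to remain within the scatter.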

Compound 4, half-maximal inhibitory concentration: 2.22 ug/mL
Beside the measured number, compound 4's estimate is 1.1-fold (0.05 log units) below it, and the stated range covers the measured number.
By their numbers in this assay, from the lowest: compounds 2, 3, 1 and 4 (each within the scatter of the next).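

Bromo, on an aromatic carbon para to a large group, joins hydrogen, methyl and nitro at this place, and in this assay the steps of a 1.1-fold higher number from compound 3 to compound 4 (0.04 log units; within the scatter) and a 1.1-fold higher number from compound 2 to compound 4 (0.05 log units; within the scatter) and a 1.0-fold higher number from compound 1 to compound 4 (0.01 log units; within the scatter) all stay within the scatter. With bromo included, all four compounds lie within the scatter of one another, so none of these groups separates from the others in this read-out. No measurement bears on why these groups give such similar numbers, and none is available to explain the result.

The compounds leave open whether an amine, a carboxylic acid or a longer chain at this carbon would give a step beyond the scatter. They also leave open whether changes elsewhere on the shared core would give such a step.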